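Carbamate to benzoate ester at the carbonyl carbon

A few compounds are considered here, and "the series" means these few. Any claim that something is new, unique, unknown or untested is made for them only; others in the source may bear on it.

Among the compounds with values here, compound 2 `O=C(NCc1ccccc1)OCC(O)Cn1cc(CN2CCN(c3ccccc3)CC2)nn1` stands highest of the two numbers so far: in an assay on nucleic acid for inhibition of Nucleic Acid, read by fluorescence, tested at 100 uM (a lower number here means less inhibition, a higher number more inhibition at the concentration tested (going by the name of the read-out)), compound 2 gives 32%, while compound 1 `CCCCNC(=O)OCC(O)Cn1cc(CN2CCN(c3ccccc3)CC2)nn1` gives 11%. Within the data shown here, the single measured step, a number 21 percentage points higher from compound 1 to compound 2 (beyond the scatter), concerns a change on a saturated chain carbon bound to an amide-type nitrogen, not the carbonyl carbon itself. Compound 3 `O=C(OCC(O)Cn1cc(CN2CCN(c3ccccc3)CC2)nn1)c1ccccc1` differs from compound 2 by phenyl in place of benzylamino on a carbonyl carbon. Among the measured compounds shown here, no measured step removes the amide-type nitrogen, so the earlier step bears only loosely on this change. No step beyond the scatter is expected: a number 4 percentage points lower from compound 2 to compound 3 (within the scatter). Compound 3 is estimated at 28%, within a range from 10% to 46%.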

Compound 3, a percentage reported as inhibition, at one concentration (the size of the read-out at that concentration, not a potency): 11%
For compound 3 the middle estimate is 17 percentage points above the measured one; the range from low to high includes it.
By their numbers in this assay, from the lowest: compounds 1 and 3 (each within the scatter of the next); then compound 2.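

In this assay, phenyl in place of benzylamino on the carbonyl carbon gives a number 21 percentage points lower from compound 2 to compound 3 (beyond the scatter) and so removes the advantage held by compound 2. Phenyl in place of butylamino gives no change at the digits printed from compound 1 to compound 3 (within the scatter) on the same carbon, so among these three compounds only the benzylamino group stands apart. No measured information explains this difference.

The compounds shown leave open whether the higher number needs the amide hydrogen, the benzyl ring, or both together. A benzyloxy or phenethylamino group on this carbonyl carbon would help separate these.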